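This account rests on a few compounds, and the source may have more. Where it says the series, first, only, none or still open, it means among the compounds named here.

Of the compounds shown here, three share one core and have been tested in a functional assay on PC-9 cells (Homo sapiens) for inhibition, read by MTT assay, with a stated time of 72 h; a lower number here means a stronger inhibitor, a higher number a weaker inhibitor. Compound 1 `Cc1cc(Nc2cc(-c3ccccc3)[nH]n2)n2nc(SCc3nc4ccccc4[nH]3)nc2n1` gives 4840 nM in this assay. Compound 3 `Cc1cc(Nc2cc(-c3cccs3)[nH]n2)n2nc(SCc3ccc(Br)cc3)nc2n1` gives 4890 nM, and compound 2 `Cc1cc(Nc2ccn(Cc3nc(C)c4ccccc4n3)n2)n2nc(SCc3ccc(Br)cc3)nc2n1` gives 5450 nM. The gaps from compound 1 to compound 3 and to compound 2 both lie within the usual scatter of this assay, so the three measured compounds cannot be told apart on these numbers, even though they differ at several places around the core.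

The next compound, compound 4 `Cc1cc(Nc2cc(-c3ccccc3)[nH]n2)n2nc(SCC3CC3)nc2n1`, differs from compound 1 in one place: cyclopropyl in place of 1H-benzimidazol-2-yl on a saturated chain carbon bound to a sulfur. Among the compounds with values here, no pair of measured compounds shows the effect of a change at this position on its own, so there is no measured step to lean on. Since the three measured compounds stay close together despite varied groups on the sulfur, only a small step is expected, from compound 1 to compound 4 a 1.3-fold higher number from compound 1 to compound 4 (0.13 log units; within the scatter), toward a weaker inhibitor if anything. Compound 4 is therefore expected to give about 6500 nM in this assay, within a range from 2500 nM to 17000 nM.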

Compound 4, half-maximal inhibitory concentration: > 50000 nM
Compound 4 gave a limit, no number; the forecaster's own chance of this, stated with the estimate: 10%; at least 7.6-fold (0.88 log units) between middle value and limit.
By their numbers in this assay, from the lowest: compounds 1, 3 and 2 (each within the scatter of the next). At a limit, above all of these: compound 4.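

The close values of the first three compounds gave no sign that the group on this saturated chain carbon bound to a sulfur matters, yet in this assay replacing 1H-benzimidazol-2-yl with cyclopropyl gives an at least 10-fold higher number from compound 1 to compound 4 (1.01 log units; beyond the scatter). For compound 4, the result of > 50000 nM is a limit of the assay, not a number. This single position can therefore decide whether a compound in this series gives a measurable value, though the true size of the step stays unknown because only a limit is available: the limit of > 50000 nM in this assay, at which 1 of the 4 values shown sits.

The change removes both aromatic rings and the hydrogen-bond donor and acceptor together, so the compounds shown do not reveal which of these features counts. On these data alone, it also remains open whether a phenyl group, an imidazol-2-yl group or a longer carbon chain at this place would keep a measurable value.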